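Adding a Second Hydroxy Group to Compound 3

The compounds below may be only part of what the source reports. "The series", "measured", "known", "first", "only" and "open" are said of these compounds alone.

Compound 1 `Cc1c(C(=O)N/N=C\c2cccc(F)c2)oc2cccc(O)c12`: >= 40000 nM
Compound 2 `Cc1c(C(=O)N/N=C\c2ccc(O)cc2)oc2cccc(O)c12`: 21700 nM
Compound 3 `Cc1c(C(=O)N/N=C\c2cccc(O)c2)oc2cccc(O)c12`: 17600 nM

Three compounds share one core and differ only in the aromatic ring attached to the carbon with a double bond to nitrogen. In a functional assay on PC-3 cells (Homo sapiens) for inhibition (a higher number here means a weaker inhibitor, a lower number a stronger inhibitor), compound 1 reaches only the limit of the assay, >= 40000 nM, and no number is known for it. Compound 2 gives 21700 nM and compound 3 gives 17600 nM. Compound 3 therefore holds the lower of the two numbers shown, but its gap to compound 2, a 1.2-fold lower number from compound 2 to compound 3 (0.09 log units; within the scatter), lies within the scatter, so the two cannot be ordered. The step of an at least 2.2-fold lower number from compound 1 to compound 3 (0.35 log units; beyond the scatter) is the only one beyond the scatter, and it is bounded by the limit of >= 40000 nM in this assay, at which 1 of the 3 values shown sits.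

Compound 4 `Cc1c(C(=O)N/N=C\c2ccc(O)cc2O)oc2cccc(O)c12` is not yet measured. It differs from compound 3 in that (2,4-dihydroxyphenyl in place of 3-hydroxyphenyl on a carbon with a double bond to nitrogen). The step that bears on it is the exchange of fluoro for hydroxy, an at least 2.2-fold lower number from compound 1 to compound 3 (0.35 log units; beyond the scatter), which favoured the hydroxy ring; the shift of hydroxy from one position to another, a 1.2-fold lower number from compound 2 to compound 3 (0.09 log units; within the scatter), changed little. A second hydroxy is therefore expected to give at most a modest gain, a 1.5-fold lower number from compound 3 to compound 4 (0.17 log units; within the scatter), and compound 4 is estimated at 12000 nM, within 5000 nM to 30000 nM.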

Compound 4, half-maximal inhibitory concentration: 14800 nM
The estimate for compound 4 lay 1.2-fold (0.09 log units) below the measured number, within the range that was stated.
By their numbers in this assay, from the lowest: compounds 4, 3 and 2 (each within the scatter of the next). At a limit, above all of these: compound 1.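

In this assay, the step of a 1.5-fold lower number from compound 2 to compound 4 (0.17 log units; within the scatter) shows that hydroxy in place of hydrogen on the aromatic ring makes no difference that can be told from the scatter. The step of a 1.2-fold lower number from compound 3 to compound 4 (0.08 log units; within the scatter) agrees with it, so on this carbon with a double bond to nitrogen, the 2,4-dihydroxyphenyl ring cannot be separated from either ring with a single hydroxy, and a second hydroxy brings no gain that can be read. Among these compounds, only the step of an at least 2.7-fold lower number from compound 1 to compound 4 (0.43 log units; beyond the scatter) lies beyond the scatter, and its true size is unknown, since the value for compound 1 is a limit and the step is only a floor: the limit of >= 40000 nM in this assay, at which 1 of the 4 values shown sits.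

On these data alone, what an amine or a carboxylic acid on this ring would do in this assay remains open, as does the effect of a methoxy group in place of either hydroxy. Also open, as far as these compounds go, is whether any replacement for the ring, such as a longer chain, would move the number beyond the scatter from the values of compounds 2, 3 and 4.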